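Pentan-3-yl in place of 3-(dimethylamino)phenoxy: working notes

The compounds below may be only part of what the source reports. "The series", "measured", "known", "first", "only" and "open" are said of these compounds alone.

- compound 1 `COc1cccc(CNCCCNc2ccnc3cc(-c4ccc(F)cc4)ccc23)c1O` gives 6840 nM 
- compound 2 `COc1cccc(CNCCCNc2ccnc3cc(Oc4cccc(N(C)C)c4)ccc23)c1O` gives 7300 nM 

For the measured compounds named here, in an ADME assay on HepG2 cells (Homo sapiens) for cytotoxicity, read by luminescence, CellTiter-Glo and ATP content, with a stated time of 72 h (a lower number here means that less compound is needed, a higher number that more compound is needed for the effect), compound 2 stands level with compound 1, the only other measured compound, and the gap between them lies within the scatter. Compound 3 `CCC(CC)c1ccc2c(NCCCNCc3cccc(OC)c3O)ccnc2c1` has not yet been measured. The change from compound 2 is pentan-3-yl in place of 3-(dimethylamino)phenoxy on an aromatic carbon, so a group with an aromatic ring gives way to one with no ring.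

Going by the values given here, only one measured step bears on this: a 1.1-fold higher number from compound 1 to compound 2 (0.03 log units; within the scatter). There, one ring-bearing group replaced another on an aromatic carbon, and the number stayed within the scatter. Neither measured compound shows a group without a ring at this place, so the evidence is thin and the range has to stay wide. On that single step, no change beyond the scatter is expected in this assay, in either direction. The estimate therefore sits close to compound 2 (7300 nM). The expected step is small (a 1.0-fold lower number from compound 2 to compound 3 (0.02 log units; within the scatter)). For compound 3 the estimated value is 7000 nM (expected range 3000 nM to 16000 nM).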

Compound 3, half-maximal effective concentration: 410 nM
Estimate against measurement, compound 3: 17-fold (1.23 log units) above; measured number below the stated range.
By their numbers in this assay, from the lowest: compound 3; then compounds 1 and 2 (each within the scatter of the next).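

In this assay, this position on the shared core turns out to be able to move the number a long way: an 18-fold lower number from compound 2 to compound 3 (1.25 log units; beyond the scatter) and a 17-fold lower number from compound 1 to compound 3 (1.22 log units; beyond the scatter), so with pentan-3-yl on this aromatic carbon much less compound is needed for the effect. For the compounds shown here, the earlier pair could not show this, since 4-fluorophenyl and 3-(dimethylamino)phenoxy lie within the scatter of each other, and across these three compounds the large difference appears only where a group with a ring gives way to one with no ring, with no compound going against it. Nothing available gives a reason for this difference, and the data neither confirm nor exclude any explanation of it.

With a single ring-free group, the compounds shown leave open whether the lower number goes with the absence of a ring, with the branched shape of pentan-3-yl, or with its smaller count of heavy atoms against that of 3-(dimethylamino)phenoxy. On these data alone, a straight pentyl chain, a cyclohexyl group and a methyl group at this place would separate these readings, and how an amine or a carboxylic acid there would read in this assay also remains open.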